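The source may hold more compounds than are shown below. What is called first, only, known or untested is meant among the compounds shown, and "the series" means these compounds.

Compound 1 `COc1ccc(OC)c(-c2cc(-c3ccccc3)nn2-c2ccc(S(N)(=O)=O)cc2)c1` gives 13000 nM in a functional assay on cells (Cancer cell lines, Homo sapiens) for cytotoxicity, read by sulforhodamine B assay, with a stated time of 48 h; a lower number here means a stronger inhibitor of growth, a higher number a weaker inhibitor of growth.
Compound 2 `COc1ccc(OC)c(-c2cc(-c3ccccc3)nn2-c2ccc(S(=O)(=O)NC(C)=O)cc2)c1` gives 13300 nM in this assay.

For the measured compounds named here, compound 1 has the lowest of the two numbers, and the only measured step, a 1.0-fold higher number from compound 1 to compound 2 (0.01 log units; within the scatter), lies within the scatter. Compound 3 `NS(=O)(=O)c1ccc(-n2nc(-c3ccccc3)cc2-c2cc(O)ccc2O)cc1` is not yet measured. It differs from compound 1 by 2,5-dihydroxyphenyl in place of 2,5-dimethoxyphenyl on an aromatic carbon. Going by the values given here, the one measured step alters a sulfonamide nitrogen, not the aryl group on the core, so no measured step bears directly on this change. Among the compounds with values here, the two compounds measured so far show that the shared core holds its number under one small change, and nothing more. For compound 3 the step is therefore expected to be small, a 1.4-fold lower number from compound 1 to compound 3 (0.16 log units; within the scatter), with a wide range to either side. The estimate for compound 3 in this assay is 9000 nM, between 2500 nM and 30000 nM.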

Compound 3, concentration for 50% growth inhibition: 88100 nM
The estimate for compound 3 lay 9.8-fold (0.99 log units) below the measured number; the measured number lies above the stated range.
By their numbers in this assay, from the lowest: compounds 1 and 2 (each within the scatter of the next); then compound 3.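

In this assay, for the compounds shown here, the aromatic carbon next to the ring nitrogen proves sensitive to the group it carries: 2,5-dihydroxyphenyl in place of 2,5-dimethoxyphenyl gives a 6.8-fold higher number from compound 1 to compound 3 (0.83 log units; beyond the scatter), whereas the only earlier step, on the sulfonamide nitrogen, stayed within the scatter. On this shared core, then, the weaker growth inhibition goes with the two hydroxyl groups and the stronger with the two methoxy groups. Nothing available explains this difference.

The compounds shown leave open whether both methoxy groups are needed, or whether a ring with one methoxy and one hydroxyl group would keep the number of compound 1. They also leave open how longer ethoxy chains or an amine on this ring would behave, and whether acetyl on the sulfonamide nitrogen would remain without consequence alongside 2,5-dihydroxyphenyl.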